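Moving a chlorine on the benzyl ether of compound 3

The compounds below may be only part of what the source reports. "The series", "measured", "known", "first", "only" and "open" are said of these compounds alone.

Of the compounds shown here, three sharing one core have been measured in a functional assay on SW-620 cells (Homo sapiens) for inhibition, read by MTT assay, with a stated time of 48 h; a lower number here means a stronger inhibitor, a higher number a weaker inhibitor. Compound 1 `Cc1ccc(NC(=O)NC(=O)c2ccc(OCc3ccccc3)cc2)cc1-c1nc2ccccc2[nH]1` gives 30100 nM. Compound 2 `Cc1ccc(NC(=O)NC(=O)c2ccc(OCc3ccccc3F)cc2)cc1-c1nc2ccccc2[nH]1` gives 4110 nM, and compound 3 `Cc1ccc(NC(=O)NC(=O)c2ccc(OCc3ccc(Cl)c(Cl)c3)cc2)cc1-c1nc2ccccc2[nH]1` gives 6100 nM. Compound 3 thus stands well apart from compound 1 and close to compound 2: the step of a 4.9-fold lower number from compound 1 to compound 3 (0.69 log units; beyond the scatter) is beyond the scatter, while a 1.5-fold higher number from compound 2 to compound 3 (0.17 log units; within the scatter) is within it. The other change in this set, a 7.3-fold lower number from compound 1 to compound 2 (0.86 log units; beyond the scatter), also places a halogen on the benzyl ring and likewise lowers the number. Compound 4 `Cc1ccc(NC(=O)NC(=O)c2ccc(OCc3ccc(Cl)cc3Cl)cc2)cc1-c1nc2ccccc2[nH]1` differs from compound 3 only in 2,4-dichlorophenyl in place of 3,4-dichlorophenyl on a saturated chain carbon bound to an oxygen on an aromatic ring. Within the data shown here, no measured step tests exactly this rearrangement of the two chlorines. The two halogen placements seen so far gave gains of similar size, and the gap between them lies within the scatter, so only a small change, if any beyond the scatter, is expected for a 1.4-fold lower number from compound 3 to compound 4 (0.13 log units; within the scatter). Compound 4 is therefore estimated at 4500 nM, within a range of 1800 nM to 12000 nM.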

Compound 4, half-maximal inhibitory concentration: 12200 nM
Estimate against measurement, compound 4: 2.7-fold (0.43 log units) below; the whole stated range lies below it.
By their numbers in this assay, from the lowest: compounds 2, 3 and 4 (each within the scatter of the next, the first and the last beyond it); then compound 1.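

In this assay, moving one chlorine to turn 3,4-dichlorophenyl into 2,4-dichlorophenyl gives a 2.0-fold higher number from compound 3 to compound 4 (0.30 log units; within the scatter), so on its own this rearrangement of the same atoms cannot be told apart from the scatter of repeated measurements. It does change the picture slightly: compound 2 and compound 3 could not be separated, whereas a 3.0-fold higher number from compound 2 to compound 4 (0.47 log units; beyond the scatter) is a real gap, and the gain over the unsubstituted phenyl survives in a 2.5-fold lower number from compound 1 to compound 4 (0.39 log units; beyond the scatter), so all three halogenated compounds keep a lower number than compound 1. Nothing available explains these differences.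

As far as these compounds go, whether a single chlorine on the benzyl ring would do as well as two remains open. So does the effect of a group of another kind there, such as a methoxy, a trifluoromethyl or an amine.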